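Moving the nitro group of compound 3

This account rests on a few compounds, and the source may have more. Where it says the series, first, only, none or still open, it means among the compounds named here.

Of the compounds shown here, three sharing one core have been measured so far in a functional assay on MCF7 cells (Homo sapiens) for cytotoxicity, read by MTT assay, with a stated time of 96 h; a higher number here means a weaker inhibitor, a lower number a stronger inhibitor. Compound 1 (`COc1cc(C(=O)c2cn(-c3ccccc3)cc2-c2cccc([N+](=O)[O-])c2)cc(OC)c1OC`) gives 50 nM, compound 2 (`COc1cc(C(=O)c2cn(-c3cccc(N)c3)cc2-c2ccccc2Cl)cc(OC)c1OC`) gives 40 nM, and compound 3 (`COc1cc(C(=O)c2cn(-c3cccc(N)c3)cc2-c2ccccc2[N+](=O)[O-])cc(OC)c1OC`) gives 14 nM, the lowest of the three numbers. Compound 4 (`COc1cc(C(=O)c2cn(-c3cccc(N)c3)cc2-c2cccc([N+](=O)[O-])c2)cc(OC)c1OC`) differs from compound 3 in one group: 3-nitrophenyl in place of 2-nitrophenyl on an aromatic carbon. In words, 3-nitrophenyl stands in place of 2-nitrophenyl on an aromatic carbon.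

Among the measured compounds shown here, only one measured step falls at this place, a 2.9-fold lower number from compound 2 to compound 3 (0.46 log units; beyond the scatter), a modest change of nitro in place of chloro. It does not show what moving the nitro group does. Compound 1 also carries 3-nitrophenyl, but it lacks the 3-aminophenyl group, and in this assay compound 1 gives 50 nM. That value points towards a higher number, so a modest step in that direction is expected, and it may stay within the scatter: a 1.8-fold higher number from compound 3 to compound 4 (0.25 log units; within the scatter). For compound 4 the estimated value is 25 nM, with an expected range from 8 nM to 80 nM.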

Compound 4, half-maximal inhibitory concentration: 510 nM
Beside the measured number, compound 4's estimate is 20-fold (1.31 log units) below it; measured number above the stated range.
By their numbers in this assay, from the lowest: compound 3; then compounds 2 and 1 (each within the scatter of the next); then compound 4.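

Moving the nitro group on this aryl ring matters far more than exchanging it for chloro did: in this assay the change to 3-nitrophenyl gives a 36-fold higher number from compound 3 to compound 4 (1.56 log units; beyond the scatter), well beyond the earlier 2.9-fold lower number from compound 2 to compound 3 (0.46 log units; beyond the scatter). Compound 4 also stands apart from the 2-chlorophenyl analogue, with a 13-fold higher number from compound 2 to compound 4 (1.11 log units; beyond the scatter), so among these three compounds only 3-nitrophenyl gives a large rise. With 3-nitrophenyl held in place, amino in place of hydrogen gives a 10-fold higher number from compound 1 to compound 4 (1.01 log units; beyond the scatter), so the amino group does not lower the number in this pair, and nothing available explains these steps.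

On these data alone, whether amino in place of hydrogen has the same effect alongside 2-nitrophenyl remains open. So does whether a nitrile or a carboxylic acid on this ring would follow the nitro or chloro compounds.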